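Demethylating an amine linker: compound 2 to compound 4

The compounds below may be only part of what the source reports. "The series", "measured", "known", "first", "only" and "open" are said of these compounds alone.

Three compounds have been measured in an assay on IM-9 cells for binding affinity to Substance-P receptor (Homo sapiens); on this read-out lower numbers stand for stronger inhibition and higher numbers for weaker inhibition:

- compound 1, `Cn1c(C(=O)NCc2cc(C(F)(F)F)cc(C(F)(F)F)c2)c(-c2ccc(F)cc2)c2cccnc2c1=O`, gives 1.1 nM
- compound 2, `COc1ccccc1CN(C)Cc1c(-c2ccccc2)c2cc(C)c(C)cc2c(=O)n1C`, gives 800 nM
- compound 3, `COc1ccccc1CN(C)C(=O)c1c(-c2ccc(F)cc2)c2cccnc2c(=O)n1C`, gives 2.5 nM

Compound 2 shows the highest number of the three, which on this read-out means the weakest inhibition. Its nearest neighbour is compound 3, whose number is far lower and beyond the usual scatter; compound 1 lies lower still. Compound 2 differs from both in more than one place, so no single structural cause for the gap can be read off.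

Compound 4, `COc1ccccc1CNCc1c(-c2ccccc2)c2cc(C)c(C)cc2c(=O)n1C`, is derived from compound 2 by one change: hydrogen in place of methyl on an amine nitrogen. The amine that carries the methoxybenzyl group becomes a secondary amine. For the measured compounds named here, the measured set contains no such pair, so the expected step in this assay can only be guessed; a small change in either direction, or none beyond the scatter, seems most plausible, since the rest of compound 2 is kept unchanged.

Compound 4 is therefore expected to give about 600 nM, within a range from 150 nM to 3000 nM, which means an estimated step of a 1.3-fold lower number from compound 2 to compound 4 (0.12 log units; within the scatter).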

Compound 4, half-maximal inhibitory concentration: 13 nM
Estimate against measurement, compound 4: 46-fold (1.66 log units) above, outside the stated range (below it).
By their numbers in this assay, from the lowest: compound 1; then compound 3; then compound 4; then compound 2.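

In this assay, putting hydrogen in place of methyl on this amine nitrogen gives a 62-fold lower number from compound 2 to compound 4 (1.79 log units; beyond the scatter), a large step beyond the usual scatter. For the compounds shown here, the earlier compounds differed from one another in more than one place, so their gaps could not be tied to any single feature; this pair is the first to link a large change in the number to one place, and only a single carbon leaves there, with no ring, charge, hydrogen-bond donor or hydrogen-bond acceptor counted among what goes. The methyl on this nitrogen therefore matters a great deal for the number in this compound pair, although nothing at hand explains why the step is so large.

The compounds shown leave open how an ethyl group or a longer chain on this same nitrogen would compare, and so whether the number rises steadily as the group grows or only the methyl stands out. They also leave open whether hydrogen in place of methyl on the amide nitrogen of compound 3 would bring a step of similar size on a different core.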